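Shortening the side chain in the fluorophenyl series

A few compounds are considered here, and "the series" means these few. Any claim that something is new, unique, unknown or untested is made for them only; others in the source may bear on it.

Measured so far in a functional assay on the whole organism (strain Swiss) with Mus musculus as the target, in the maximal electroshock model, with a stated time of 0.5 h, at a dose of 300 mg/kg by the intraperitoneal route; a lower number here means a weaker effect, a higher number a stronger effect of the compound at the dose given:
compound 1, `COc1cccc(N2CCN(C(=O)C(C)N3C(=O)CCC3=O)CC2)c1`: 50%
compound 2, `CCC(C(=O)N1CCN(c2cccc(OC)c2)CC1)N1C(=O)CCC1=O`: 0%
compound 3, `CCC(C(=O)N1CCN(c2ccc(F)cc2)CC1)N1C(=O)CCC1=O`: 25%

Compound 2 is the starting point for both comparisons. Going to compound 1 means the change (hydrogen in place of methyl on a saturated chain carbon, two bonds along the chain from an amide-type nitrogen in a ring and a carbonyl carbon), and in this assay it brought a number 50 percentage points higher from compound 2 to compound 1 (beyond the scatter). Going to compound 3 instead means the change (4-fluorophenyl in place of 3-methoxyphenyl on an amine nitrogen in a ring), which brought a number 25 percentage points higher from compound 2 to compound 3 (beyond the scatter). Compound 3 thus sits between the other two measured compounds, below compound 1 and above compound 2.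

Compound 4, `CC(C(=O)N1CCN(c2ccc(F)cc2)CC1)N1C(=O)CCC1=O`, has not yet been measured. It differs from compound 3 by hydrogen in place of methyl on a saturated chain carbon, two bonds along the chain from an amide-type nitrogen in a ring and a carbonyl carbon. This is the same change that leads from compound 2 to compound 1: the group that leaves, the group that enters and the place where it happens are described in identical words. What separates the two pairs is the core: the core of compound 3 differs from that of compound 2 by 4-fluorophenyl in place of 3-methoxyphenyl on an amine nitrogen in a ring.

Within the data shown here, the only guide is the single earlier step. Because a number 50 percentage points higher from compound 2 to compound 1 (beyond the scatter) was large, a step in the same direction is expected from compound 3 to compound 4, estimated at a number 35 percentage points higher from compound 3 to compound 4 (beyond the scatter). Since that step rests on one example in a different core, the estimate for compound 4 is held wide, at 60% with a likely range from 30% to 90%.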

Compound 4, a percentage reported as activity, at one dose (the size of the read-out at that dose, not a potency): 50%
Compound 4: the middle estimate sits 10 percentage points above what was measured; low and high end bracket the measured number.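

In this assay, hydrogen in place of methyl on the chain again gives a higher number, a number 25 percentage points higher from compound 3 to compound 4 (beyond the scatter), so the direction of the step holds on both cores, but its size does not: the same change on two cores in this assay, a number 50 percentage points higher (beyond the scatter) from compound 2 to compound 1 and a number 25 percentage points higher (beyond the scatter) from compound 3 to compound 4, 25 percentage points apart, beyond the scatter of two such steps

The other change, 4-fluorophenyl in place of 3-methoxyphenyl, also differs in size with the group on the chain, giving no change at the digits printed from compound 1 to compound 4 (within the scatter) when that group is methyl rather than ethyl: the same change on two cores in this assay, a number 25 percentage points higher (beyond the scatter) from compound 2 to compound 3 and no change at the digits printed (within the scatter) from compound 1 to compound 4, 25 percentage points apart, beyond the scatter of two such steps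

These two pairs show that the effect of each change depends on the rest of the molecule, so neither can be carried to another compound as a fixed increment, but they do not show why the sizes differ or whether the direction would hold on any further core.

The compounds shown leave open what happens if the chain is lengthened to propyl, or if the methyl left on the chain carbon of compound 4 is also replaced by hydrogen. They also leave open how a chlorine or a nitrile in place of the fluorine would behave, and whether compound 1 and compound 4 would still match at a lower dose.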